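Swapping the aryl neighbour: from methylfuran to pyrazine

The source may hold more compounds than are shown below. What is called first, only, known or untested is meant among the compounds shown, and "the series" means these compounds.

Compounds measured so far in a functional assay for activation of Alpha-1B adrenergic receptor (Homo sapiens), read by calcium flux; a lower number here means that less compound is needed, a higher number that more compound is needed for the effect:
Compound 1, `Cc1nc(-c2ccccc2NCC2=NCCN2)cs1`, gives 69.2 nM.
Compound 2, `Cc1cc(-c2ccccc2NCC2=NCCN2)on1`, gives 95.5 nM.
Compound 3, `Cc1ccc(-c2ccccc2NCC2=NCCN2)o1`, gives 46.8 nM.

All three share the same core and differ only in the small aromatic ring attached to it. Compound 3 carries the lowest number of the three, although its gap to compound 1 is within the scatter, so the two cannot be ranked; only compound 2 sits clearly apart, as a 2.0-fold lower number from compound 2 to compound 3 (0.31 log units; beyond the scatter) shows. The other swaps changed little: a 1.4-fold higher number from compound 1 to compound 2 (0.14 log units; within the scatter) and a 1.5-fold lower number from compound 1 to compound 3 (0.17 log units; within the scatter).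

Compound 4, `c1ccc(-c2cnccn2)c(NCC2=NCCN2)c1`, has not yet been measured. It differs from compound 3 in one place: pyrazin-2-yl in place of 5-methylfuran-2-yl on an aromatic carbon. The swaps seen so far all moved the number by small amounts, but each of them exchanged one five-membered ring for another; the new ring is six-membered and of a different kind, so a somewhat larger shift in this assay is plausible. A modest rise in the number is therefore expected, a 2.1-fold higher number from compound 3 to compound 4 (0.33 log units; beyond the scatter). For compound 4 the estimate is 100 nM, with a likely range from 30 nM to 400 nM.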

Compound 4, half-maximal effective concentration: 339 nM
Compound 4: the middle estimate sits 3.4-fold (0.53 log units) below what was measured; the range from low to high includes it.
By their numbers in this assay, from the lowest: compounds 3, 1 and 2 (each within the scatter of the next, the first and the last beyond it); then compound 4.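

The ring on this aromatic carbon matters more than the three five-membered rings suggested: pyrazin-2-yl gives a 7.2-fold higher number from compound 3 to compound 4 (0.86 log units; beyond the scatter) and the other two comparisons agree, with a 3.5-fold higher number from compound 2 to compound 4 (0.55 log units; beyond the scatter) and a 4.9-fold higher number from compound 1 to compound 4 (0.69 log units; beyond the scatter). Each of these steps is beyond the scatter and larger than any step among compounds 1, 2 and 3, so the near-flat picture held only for those five-membered rings. Pyrazin-2-yl also differs from all three in carrying no methyl group, so this one swap changes ring size, ring hetero atoms and the methyl together.

A plain phenyl ring, a pyridin-2-yl ring or a methyl-bearing pyrazine would help to pull these changes apart. Nothing available here indicates why the number rises.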